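The source may report more compounds than this note shows. Statements on the series, on what has been measured and on what is new or still open speak of the compounds shown alone.

Measured so far:
- compound 1 `O=C(Nc1cc(C(F)(F)F)cc(C(F)(F)F)c1)c1cnc(Cl)nc1C(F)(F)C(F)(F)F`: 800 nM
- compound 2 `O=C(Nc1cc(C(F)(F)F)cc(C(F)(F)F)c1)c1cnc(C(F)(F)F)nc1Cl`: > 10000 nM
- compound 3 `O=C(Nc1cc(C(F)(F)F)cc(C(F)(F)F)c1)c1ccc(Cl)cc1C(F)(F)F`: > 30000 nM

Within the data shown here, in an assay on Jurkat cells for activation of nuclear factor NF-kappa-B complex (Homo sapiens) (a lower number here means a stronger inhibitor, a higher number a weaker inhibitor), compound 1 gives 800 nM, the only plain number among the three values recorded so far. For compound 2 the entry > 10000 nM is a limit of this assay and not a number (the limit of > 10000 nM in this assay, at which 1 of the 3 values shown sits). For compound 3 the entry > 30000 nM is likewise a limit (the limit of > 30000 nM in this assay, at which 1 of the 3 values shown sits). Compound 1 therefore stands as the sole measured reference point of the series; nothing can be placed above or below it with a known gap.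

Compound 4 `O=C(Nc1cc(C(F)(F)F)cc(C(F)(F)F)c1)c1cnc(Cl)nc1C(F)(F)F` differs from compound 1 in one place: fluoro in place of trifluoromethyl on a saturated chain carbon bound to an aromatic carbon and two fluorine atoms. Among the measured compounds shown here, no pair of measured compounds tracks this change, so no measured step speaks to its size or direction. The expectation is a step from compound 1 to compound 4 of a 2.5-fold higher number from compound 1 to compound 4 (0.40 log units; beyond the scatter), that is, a modest shift toward weaker inhibition that may still sit close to the scatter. On that basis compound 4 is expected to give about 2000 nM, with a range of 500 nM to 8000 nM.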

Compound 4, half-maximal inhibitory concentration: 50 nM
For compound 4 the middle estimate is 40-fold (1.60 log units) above the measured one; measured number below the stated range.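

In this assay, going from 1,1,2,2,2-pentafluoroethyl to trifluoromethyl on the shared core gives a 16-fold lower number from compound 1 to compound 4 (1.20 log units; beyond the scatter). Among these compounds, this is the first measured step: this place on the core responds strongly to the length of the fluorinated chain, and of this pair the shorter trifluoromethyl group gives the stronger inhibitor. Nothing measured here bears on why the step is this large.

Still open, from the compounds shown here alone, is whether a methyl group or a plain hydrogen at this place would keep the stronger inhibition, and whether a longer chain such as heptafluoropropyl would weaken it further. Also open, going by these compounds, is what an amine in place of the chloro group would do on the core of compound 4.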